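Phenyl in Place of Methyl on Two Related Cores

The source may report more compounds than this note shows. Statements on the series, on what has been measured and on what is new or still open speak of the compounds shown alone.

Three compounds have been measured in an assay on HEK293 cells for displacement of a labelled ligand from Neuronal acetylcholine receptor; alpha4/beta2 (Rattus norvegicus), with a stated time of 4 h; a lower number here means a stronger inhibitor, a higher number a weaker inhibitor:

Compound 1, `CCO[C@H]1CC[C@H]2CCN(C)[C@H]2C1`, gives 300000 nM
Compound 2, `CN1CC[C@@H]2CC[C@H](OCc3ccccc3)C[C@@H]21`, gives 100000 nM
Compound 3, `CCO[C@H]1CC=C2CCN(C)[C@H]2C1`, gives 300000 nM

All three numbers are high, so each compound displaces the labelled ligand only weakly. Compound 1 and compound 2 differ in one place, namely (phenyl in place of methyl on a saturated chain carbon bound to an oxygen on a saturated carbon). This change produced a 3.0-fold lower number from compound 1 to compound 2 (0.48 log units; beyond the scatter), a step that lies beyond the usual scatter, although compound 2 still counts as a weak binder. Compound 3 stands level with compound 1 at the digits given, and the two values lie within the scatter of each other; how the core of compound 3 differs from the core of compound 1 is not broken down here.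

Compound 4, `CN1CCC2=CC[C@H](OCc3ccccc3)C[C@@H]21`, has not yet been measured. It differs from compound 3 by phenyl in place of methyl on a saturated chain carbon bound to an oxygen on a saturated carbon, which is the same change that separates compound 2 from compound 1, made at the same place. The expected step in this assay is a 3.0-fold lower number from compound 3 to compound 4 (0.48 log units; beyond the scatter), and this expectation rests on the earlier step of a 3.0-fold lower number from compound 1 to compound 2 (0.48 log units; beyond the scatter) seen on the core of compound 1. The expected value for compound 4 in this assay is therefore 100000 nM, with a likely range estimated from 40000 nM to 300000 nM. Going by the values given here, only one example of this change is at hand, so the estimate is uncertain; the step on the core of compound 3 could be smaller or could fail to appear.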

Compound 4, inhibition constant: 300000 nM
Compound 4: middle estimate off by 3.0-fold (0.48 log units), on the low side; the measured number falls inside the stated range.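

In this assay, phenyl in place of methyl on the core of compound 3 gave no change at the digits printed from compound 3 to compound 4 (within the scatter), so the gain seen on the core of compound 1 did not reappear. In this series, then, the effect of this change cannot simply be carried from one core to the other, and the two results really do differ: the same change on two cores in this assay, a 3.0-fold lower number (0.48 log units; beyond the scatter) from compound 1 to compound 2 and no change at the digits printed (within the scatter) from compound 3 to compound 4, 3.0-fold (0.48 log units) apart, beyond the scatter of two such steps. This does not show which feature of the two cores matters, and with a single pair on each core it gives no general rule, nor does it say how any other change would behave on these cores; all four compounds also remain weak binders, so the comparison concerns only small differences among high numbers.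

From the compounds shown here alone, it remains open how other groups at the same place, on a saturated chain carbon bound to an oxygen on a saturated carbon, would behave on the two cores, for example an amine, a carboxylic acid or a longer chain in place of the phenyl. Going by these compounds, it is equally open whether any such group would give a step that appears on both cores, or a number much lower than those seen so far.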